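The source may report more compounds than this note shows. Statements on the series, on what has been measured and on what is new or still open speak of the compounds shown alone.

For the measured compounds named here, compound 2 `COc1ccc(Nc2ncnc3cc(NC(=O)CCCCCCC(=O)NO)sc23)c(C)c1` gives 1980 nM in a functional assay on RPMI-8226 cells (Homo sapiens) for antiproliferative activity, read by radiometric assay, with a stated time of 72 h (a lower number here means a stronger inhibitor, a higher number a weaker inhibitor), one of only two numbers measured, and the two sit within the scatter of each other. Compound 1 `Cc1cc(F)ccc1Nc1ncnc2cc(NC(=O)CCCCCCC(=O)NO)sc12` gives 1950 nM in this assay, and the step measured was a 1.0-fold higher number from compound 1 to compound 2 (0.01 log units; within the scatter). Compound 3 `N#Cc1cccc(Nc2ncnc3cc(NC(=O)CCCCCCC(=O)NO)sc23)c1` differs from compound 2 by 3-cyanophenyl in place of 4-methoxy-2-methylphenyl on a nitrogen on an aromatic ring. Going by the values given here, no measured step changes the group on that nitrogen; the single step recorded lay elsewhere and stayed within the scatter, so it gives no direction. Compound 3 is therefore expected to show a 1.0-fold higher number from compound 2 to compound 3 (0.00 log units; within the scatter), nothing beyond the scatter. The estimated value of compound 3 is 2000 nM, with a range from 600 nM to 7000 nM.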

Compound 3, half-maximal inhibitory concentration: 1580 nM
For compound 3 the middle estimate is 1.3-fold (0.10 log units) above the measured one; low and high end bracket the measured number.
By their numbers in this assay, from the lowest: compounds 3, 1 and 2 (each within the scatter of the next).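

For the compounds shown here, the group on the nitrogen on an aromatic ring now has measured steps, which the earlier compounds did not provide. In this assay, 3-cyanophenyl in place of 4-methoxy-2-methylphenyl gives a 1.3-fold lower number from compound 2 to compound 3 (0.10 log units; within the scatter) and in place of 4-fluoro-2-methylphenyl gives a 1.2-fold lower number from compound 1 to compound 3 (0.09 log units; within the scatter) so both exchanges leave the number within the scatter and show no direction at this position. Nothing beyond these numbers bears on the result. From the compounds shown here alone, whether an amine or a carboxylic acid on this phenyl would move the number beyond the scatter remains open. So does the effect of a longer chain.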